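The source may hold more compounds than are shown below. What is called first, only, known or untested is meant among the compounds shown, and "the series" means these compounds.

Measured in a functional assay on MCF7 cells (Homo sapiens) for cytotoxicity, read by ELISA, with a stated time of 4 days; on this read-out higher numbers stand for weaker inhibition and lower numbers for stronger inhibition:
compound 1 `Cc1ccsc1-c1cc(-c2ccoc2)cc(-c2ccc(Cl)cc2)n1`: 20300 nM
compound 2 `Clc1ccc(-c2cc(-c3ccco3)cc(-c3ccc(Cl)s3)n2)cc1`: 1520 nM
compound 3 `Cc1ccc(-c2cc(-c3ccoc3)cc(-c3ccc(Cl)s3)n2)o1`: 1900 nM

Compound 3, at 1900 nM, lies within the scatter of compound 2, at 1520 nM. Compound 1, at 20300 nM, stands well beyond the scatter on the weaker side of compound 3. Among the measured compounds shown here, no two measured compounds differ in one place only, so no measured step bears directly on the next change.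

The next compound is compound 4 `Clc1cccc(-c2cc(-c3ccoc3)cc(-c3ccc(Cl)s3)n2)c1`, reached from compound 3 by putting 3-chlorophenyl in place of 5-methylfuran-2-yl on an aromatic carbon. Compound 4 keeps the 5-chlorothiophen-2-yl and furan-3-yl groups of compound 3. Compound 2 also pairs 5-chlorothiophen-2-yl with a chlorophenyl group and gives 1520 nM. Against any simple reading, compound 1 carries a chlorophenyl group without 5-chlorothiophen-2-yl and gives 20300 nM, so a chlorophenyl group alone does not go with the lower numbers.

In this assay no change beyond the scatter is expected, and the expected step is a 1.1-fold lower number from compound 3 to compound 4 (0.02 log units; within the scatter). For compound 4 the estimated value is 1800 nM, with an expected range from 600 nM to 5500 nM.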

Compound 4, half-maximal inhibitory concentration: 2920 nM
Beside the measured number, compound 4's estimate is 1.6-fold (0.21 log units) below it, and the stated range covers the measured number.
By their numbers in this assay, from the lowest: compounds 2, 3 and 4 (each within the scatter of the next); then compound 1.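

Among the compounds shown here, compound 3 and compound 4 form the first pair that differs in one place, and in this assay the exchange of 5-methylfuran-2-yl for 3-chlorophenyl on the aromatic carbon next to the ring nitrogen gives a 1.5-fold higher number from compound 3 to compound 4 (0.19 log units; within the scatter) as its step. At this position, with 5-chlorothiophen-2-yl and furan-3-yl held fixed, a five-membered aromatic ring with a hetero atom and a six-membered aromatic ring of carbon only are therefore not separated by this read-out, and the hydrogen-bond acceptor counted on the leaving group is not needed to stay within the scatter. No measurement at hand accounts for this similarity.

Still open, from the compounds shown here alone, is how a non-aromatic group at this position would read, such as a saturated amine like piperidine, a carboxylic acid or a longer alkyl chain. Also open, going by these compounds, is what the chlorine of 3-chlorophenyl contributes, and whether plain phenyl or the 4-chlorophenyl isomer would stay within the scatter of compound 4.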